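Chloro in Place of Methoxy on the Phenyl Ring

A few compounds are considered here, and "the series" means these few. Any claim that something is new, unique, unknown or untested is made for them only; others in the source may bear on it.

Compound 1, `NS(=O)(=O)NCC1CCN(c2cc(-c3ccccc3)ncn2)CC1`, in a functional assay on MDA-MB-231 cells (Homo sapiens) for antiproliferative activity (on this read-out higher numbers stand for weaker inhibition of growth and lower numbers for stronger inhibition of growth), compound 1 gives a limit of > 100000 nM.
Compound 2, `COc1ccc(-c2cc(N3CCC(CNS(N)(=O)=O)CC3)ncn2)cc1`, in this assay compound 2 gives a limit of > 100000 nM.
Compound 3, `COc1ccccc1-c1cc(N2CCC(CNS(N)(=O)=O)CC2)ncn1`, in this assay compound 3 gives a limit of > 100000 nM.

Compound 3 thus stands at a limit of this assay, not at a number, and its two companions stand at the same limit. The step to compound 4, `NS(=O)(=O)NCC1CCN(c2cc(-c3ccccc3Cl)ncn2)CC1`, is chloro in place of methoxy on an aromatic carbon. The measured steps that touch the same phenyl ring are a step that the two limits leave unreadable from compound 1 to compound 3 and a step that the two limits leave unreadable from compound 2 to compound 3, and a step that the two limits leave unreadable from compound 1 to compound 2; none of them can be read, because of the limit of > 100000 nM in this assay, at which 3 of the 3 values shown sit. Among the measured compounds shown here, no size of step in this assay can therefore be derived from these compounds, in either direction. The most that can be said is that every measured change on this ring has left the compound at the limit, so compound 4 is expected to do the same, with a step of a number no higher from compound 3 to compound 4 (the limit leaves the size open). Compound 4 is estimated at 100000 nM, within 30000 nM to 300000 nM.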

Compound 4, concentration for 50% growth inhibition: > 100000 nM
Compound 4 gave a limit, no number (the forecaster's own chance of this, stated with the estimate: 75%); the middle value sits exactly at the limit.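

In this assay compound 4 gives > 100000 nM, a limit and not a number. Among the compounds shown here, no step joining compound 4 to compound 1, compound 2 or compound 3 can be read: the limit of > 100000 nM in this assay, at which 4 of the 4 values shown sit. The compounds shown leave open whether any change on the phenyl ring alters growth inhibition at all.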